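Swapping 3-nitrophenyl for 2,3,4-trifluorophenyl: what to expect

The compounds below may be only part of what the source reports. "The series", "measured", "known", "first", "only" and "open" are said of these compounds alone.

In a functional assay on A549 cells (Homo sapiens) for cytotoxicity, read by MTT assay, with a stated time of 48 h (on this read-out lower numbers stand for stronger inhibition and higher numbers for weaker inhibition), compound 1 (`CC(C)=CCC/C(C)=C/CC/C(C)=C/CC[C@@H]1[C@@]2(C)CC/C(=N\OCc3cn(-c4cccc(Br)c4)nn3)C(C)(C)[C@@H]2CC[C@@]1(C)O`) gives 11700 nM and compound 2 (`CC(C)=CCC/C(C)=C/CC/C(C)=C/CC[C@@H]1[C@@]2(C)CC/C(=N\OCc3cn(-c4cccc([N+](=O)[O-])c4)nn3)C(C)(C)[C@@H]2CC[C@@]1(C)O`) gives 14800 nM. These two numbers lie level with each other, so compound 2 stands together with compound 1 and not apart from it. Compound 3 (`CC(C)=CCC/C(C)=C/CC/C(C)=C/CC[C@@H]1[C@@]2(C)CC/C(=N\OCc3cn(-c4ccc(F)c(F)c4F)nn3)C(C)(C)[C@@H]2CC[C@@]1(C)O`) keeps the shared core of compound 2 and changes one group: 2,3,4-trifluorophenyl in place of 3-nitrophenyl on an aromatic nitrogen. In short, 2,3,4-trifluorophenyl comes in place of 3-nitrophenyl on an aromatic nitrogen. Among the measured compounds shown here, only one measured step bears on this: a 1.3-fold higher number from compound 1 to compound 2 (0.10 log units; within the scatter), where nitro took the place of bromo on an aromatic carbon. For the measured compounds named here, that is thin evidence, and no fluorinated compound has been measured. The expectation in this assay is therefore no step beyond the scatter, in either direction. The expected step is a 1.1-fold lower number from compound 2 to compound 3 (0.06 log units; within the scatter). For compound 3 the estimated value is 13000 nM, with an expected range from 6500 nM to 27000 nM.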

Compound 3, half-maximal inhibitory concentration: 26900 nM
Estimate against measurement, compound 3: 2.1-fold (0.32 log units) below; the range from low to high includes it.
By their numbers in this assay, from the lowest: compounds 1, 2 and 3 (each within the scatter of the next, the first and the last beyond it).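

At this position on the aromatic nitrogen, this assay shows a 1.8-fold higher number from compound 2 to compound 3 (0.26 log units; within the scatter), so 2,3,4-trifluorophenyl does not stand apart from 3-nitrophenyl. Against 3-bromophenyl, the same group gives a 2.3-fold higher number from compound 1 to compound 3 (0.36 log units; beyond the scatter), a modest step and the first in this set to clear the scatter, showing that the choice of aromatic group here can shift the number towards weaker inhibition, if only slightly. Nothing available gives a reason for this small shift.

On these data alone, all three compounds carry a substituted phenyl ring here, so it remains open whether a plain phenyl, a benzyl group, or a phenyl ring bearing an amine or a carboxylic acid would move the number further. As far as these compounds go, it is also open whether any group at this position can bring the number clearly below that of compound 1.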